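Sulfonyl sulfur replacement from compound 1 to compound 4

This account rests on a few compounds, and the source may have more. Where it says the series, first, only, none or still open, it means among the compounds named here.

In an ADME assay on the whole organism (blood, Mus musculus, strain C57BL/6) for pharmacokinetics, read by HPLC, with a stated time of 4 h, at a dose of 2 mg/kg by the intraperitoneal route (a lower number here means less compound in the circulation, a higher number more compound in the circulation at the dose given), compound 1 (`CC(C)S(=O)(=O)c1c(Cl)ccc(NC(=O)Nc2cccc(F)c2Cl)c1O`) gives 198 ng.h/mL as its reading, compound 3 (`C[C@@H]1CN(S(=O)(=O)c2c(Cl)ccc(NC(=O)Nc3cccc(F)c3Cl)c2O)C[C@H](C)O1`) gives 279 ng.h/mL and compound 2 (`CN1CC[C@H](S(=O)(=O)c2c(Cl)ccc(NC(=O)Nc3cccc(F)c3Cl)c2O)C1`) gives 432 ng.h/mL on the same measure. Compound 1 thus stands within the scatter of compound 3 and beyond the scatter of compound 2, on the lower side.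

Compound 4 (`CC(C)N1CCN(S(=O)(=O)c2c(Cl)ccc(NC(=O)Nc3cccc(F)c3Cl)c2O)CC1`) carries 4-isopropylpiperazin-1-yl in place of isopropyl on a sulfonyl sulfur.

Two measured steps change that same place: one with 1-methylpyrrolidin-3-yl (a 2.2-fold higher number from compound 1 to compound 2 (0.34 log units; beyond the scatter)) and one with 2,6-dimethylmorpholin-4-yl (a 1.4-fold higher number from compound 1 to compound 3 (0.15 log units; within the scatter)). The two replacements compare as follows (a 1.5-fold lower number from compound 2 to compound 3 (0.19 log units; within the scatter)). Only the first step clears the scatter, and modestly, and neither replacement is the group in compound 4. A small upward move is therefore expected in this assay and none beyond the scatter. The estimated step is a 1.5-fold higher number from compound 1 to compound 4 (0.18 log units; within the scatter) and no more than that is expected. Compound 4 is estimated at 300 ng.h/mL with a range of 140 ng.h/mL to 640 ng.h/mL expected.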

Compound 4, area under the concentration-time curve: 52.9 ng.h/mL
Compound 4: the middle estimate sits 5.7-fold (0.75 log units) above what was measured; the measured number lies below the stated range.
By their numbers in this assay, from the lowest: compound 4; then compounds 1, 3 and 2 (each within the scatter of the next, the first and the last beyond it).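

In this assay, going by these compounds alone, the place on the sulfonyl sulfur proves able to lower the reading as well as raise it: 4-isopropylpiperazin-1-yl in place of isopropyl gives a 3.7-fold lower number from compound 1 to compound 4 (0.57 log units; beyond the scatter), whereas the only earlier step beyond the scatter at this place, a 2.2-fold higher number from compound 1 to compound 2 (0.34 log units; beyond the scatter), went upward. The new group also sits beyond the scatter of both other replacements, with a 5.3-fold lower number from compound 3 to compound 4 (0.72 log units; beyond the scatter) and an 8.2-fold lower number from compound 2 to compound 4 (0.91 log units; beyond the scatter), so compound 4 alone occupies the low end of the series. Nothing at hand gives a reason for this drop.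

As far as these compounds go, it remains open whether the drop belongs to the piperazine ring or to the isopropyl on it. An unsubstituted piperazin-1-yl and a 4-methylpiperazin-1-yl on the same sulfur would separate these two parts of the group.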